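The source may report more compounds than this note shows. Statements on the series, on what has been measured and on what is new or still open speak of the compounds shown alone.

Within the data shown here, in a physicochemical assay for lipophilicity, measured as octanol-water partition (on this read-out lower numbers stand for lower lipophilicity and higher numbers for higher lipophilicity), compound 1 `O=C(NNc1ccnc2cc(Cl)ccc12)c1ccccc1/N=C/c1ccc(Cl)cc1` gives 5.62 as the lowest of three numbers so far, with compound 2 `O=C(NNc1ccnc2cc(Cl)ccc12)c1ccccc1/N=C/c1ccc(Cl)cc1Cl` at 6.22 and compound 3 `O=C(NNc1ccnc2cc(Cl)ccc12)c1ccccc1/N=C/c1ccc(Cl)c(Cl)c1` at 6.22 both above it. Compound 4 `Cc1ccc(/C=N/c2ccccc2C(=O)NNc2ccnc3cc(Cl)ccc23)cc1` is still unmeasured and differs from compound 1 by methyl in place of chloro on an aromatic carbon, para to a large group (methyl in place of chloro on an aromatic carbon). The closest evidence is chloro in place of hydrogen on an aromatic carbon, with a number 0.60 log units higher from compound 1 to compound 2 (beyond the scatter) and a number 0.60 log units higher from compound 1 to compound 3 (beyond the scatter) as its two cases, whereas no change at the digits printed from compound 2 to compound 3 (within the scatter) came with 3,4-dichlorophenyl in place of 2,4-dichlorophenyl. Those chloro steps add a group where hydrogen stood. Among the measured compounds shown here, this one swaps one group for another, and no measured step covers it. The expected change in this assay is therefore small, an estimated a number 0.12 log units lower from compound 1 to compound 4 (within the scatter) that stays within the scatter. The estimate for compound 4 is 5.5 within a range of 5.1 to 5.9 as its lower and upper ends.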

Compound 4, partition coefficient: 5.31
Compound 4: the middle estimate sits 0.19 log units above what was measured; measured number inside the range.
By their numbers in this assay, from the lowest: compound 4; then compound 1; then compounds 2 and 3 (each within the scatter of the next).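

In this assay the change from 4-chlorophenyl to 4-methylphenyl at this position gives a number 0.31 log units lower from compound 1 to compound 4 (beyond the scatter) and so shows that swapping one heavy atom for another can move the number beyond the scatter. The gap is wider against the two compounds with a second chloro group, with a number 0.91 log units lower from compound 3 to compound 4 (beyond the scatter) and a number 0.91 log units lower from compound 2 to compound 4 (beyond the scatter) as the steps. Nothing available gives a reason for these differences.

As far as these compounds go, how an amine or a carboxylic acid in the same place would read in this assay stays open. So does whether methyl in place of chloro gives a similar step when a second chloro group stays on the ring.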